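From 3-hydroxyphenyl to 2,4-dichlorophenyl

The compounds below may be only part of what the source reports. "The series", "measured", "known", "first", "only" and "open" are said of these compounds alone.

compound 1 `COc1cc(-n2cnc3ccc(-c4ccccc4)cc32)cc(OC)c1OC` gives 2290 nM
compound 2 `COc1cc(-n2cnc3ccc(-c4cccc(Cl)c4)cc32)cc(OC)c1OC` gives 3120 nM
compound 3 `COc1cc(-n2cnc3ccc(-c4cccc(O)c4)cc32)cc(OC)c1OC` gives 350 nM

In a functional assay on MCF7 cells (Homo sapiens) for antiproliferative activity, read by MTT assay, with a stated time of 72 h (a lower number here means a stronger inhibitor, a higher number a weaker inhibitor), compound 3 has the lowest of the three numbers, and its steps to both others lie beyond the scatter. Compound 4 `COc1cc(-n2cnc3ccc(-c4ccc(Cl)cc4Cl)cc32)cc(OC)c1OC` carries 2,4-dichlorophenyl in place of 3-hydroxyphenyl on an aromatic carbon on the same core. Among the measured compounds shown here, two measured steps concern the hydroxy group: a 6.5-fold lower number from compound 1 to compound 3 (0.82 log units; beyond the scatter) and an 8.9-fold lower number from compound 2 to compound 3 (0.95 log units; beyond the scatter). The chloro step is a 1.4-fold higher number from compound 1 to compound 2 (0.13 log units; within the scatter). For the measured compounds named here, no measured compound carries the 2,4-dichlorophenyl group. Compound 4 lacks the hydroxy group, so a modest rise to a higher number is expected in this assay. The expected change is an 8.6-fold higher number from compound 3 to compound 4 (0.93 log units; beyond the scatter). For compound 4 the estimated value is 3000 nM, with an expected range of 1200 nM to 8000 nM.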

Compound 4, half-maximal inhibitory concentration: 5420 nM
Compound 4: middle estimate off by 1.8-fold (0.26 log units), on the low side; low and high end bracket the measured number.
By their numbers in this assay, from the lowest: compound 3; then compounds 1, 2 and 4 (each within the scatter of the next, the first and the last beyond it).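

In this assay, the step of a 15-fold higher number from compound 3 to compound 4 (1.19 log units; beyond the scatter) is the largest seen so far at this position. Of the two chlorinated compounds, the step is only a 1.7-fold higher number from compound 2 to compound 4 (0.24 log units; within the scatter), whereas the step from the unsubstituted phenyl, a 2.4-fold higher number from compound 1 to compound 4 (0.37 log units; beyond the scatter), does separate the two compounds. Compound 3 thus stays alone at the low end, with neither chlorinated compound coming near it.

The compounds shown leave open whether a methoxy group or an amine on that phenyl ring would keep the low number of compound 3. No measurement available here accounts for these differences.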